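The compounds below may be only part of what the source reports. "The series", "measured", "known", "first", "only" and "open" are said of these compounds alone.

Three analogues on a shared core have been run in a functional assay on HCT-116 cells (Homo sapiens) for cytotoxicity, read by MTT assay, with a stated time of 72 h; on this read-out higher numbers stand for weaker inhibition and lower numbers for stronger inhibition. Compound 1 `C[C@@H](Nc1c(C(=O)NCc2ccc(F)cc2)nc(Br)c2cccnc12)c1ccccc1` gives only a limit in this assay, > 20000 nM. Compound 2 `COC(=O)CNc1c(C(=O)NCc2ccc(F)cc2)nc(Br)c2cccnc12` likewise gives a limit, > 10000 nM. Compound 3 `O=C(NCc1ccc(F)cc1)c1nc(Br)c2cccnc2c1N1CCNCC1` also yields no number, only the limit > 10000 nM. With all three values at limits, none of the steps between them can be read: a step that the two limits leave unreadable from compound 1 to compound 2, a step that the two limits leave unreadable from compound 1 to compound 3, a step that the two limits leave unreadable from compound 2 to compound 3. The picture is two values at the limit of > 10000 nM in this assay, at which 2 of the 3 values shown sit, and one at the limit of > 20000 nM in this assay, at which 1 of the 3 values shown sits, with nothing to rank. Compound 3 stands at one of these limits and cannot be separated from the other two.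

The next compound, compound 4 `NCCCNc1c(C(=O)NCc2ccc(F)cc2)nc(Br)c2cccnc12`, differs from compound 3 in one place: (3-aminopropyl)amino in place of piperazin-1-yl on an aromatic carbon. Going by the values given here, no measured step bears on this change in a readable way; the three steps that exist are all unreadable, so their sizes give no guide to direction or magnitude. Among the compounds with values here, the only expectation the numbers support is that compound 4 stays in the region of the limits, and the estimate is therefore weak. Compound 4 is expected to give about 10000 nM, with a range from 3000 nM to 30000 nM. The step this estimate means is expected to be a number no higher from compound 3 to compound 4 (the limit leaves the size open).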

Compound 4, half-maximal inhibitory concentration: > 20000 nM
Compound 4 gave a limit, no number (the forecaster's own chance of this, stated with the estimate: 70%); at least 2.0-fold (0.30 log units) between middle value and limit.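

In this assay compound 4 gives only a limit, > 20000 nM, so with compound 1, compound 2 and compound 3 also at limits, none of its steps to those three can be read. The compounds shown leave open whether any group at this aromatic carbon of the shared core gives a measurable value, and how these groups rank.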